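Swapping the aryl end of compound 1 for furan

This account rests on a few compounds, and the source may have more. Where it says the series, first, only, none or still open, it means among the compounds named here.

compound 1 `COc1ccc(/C=N/NC(=S)NC(C)(C)[C@H]2CC=C(C)CC2)cc1`: 21200 nM
compound 2 `CC1=CC[C@H](C(C)(C)NC(=S)N/N=C/c2ccc(N(C)C)cc2)CC1`: > 100000 nM (a limit)
compound 3 `CC1=CC[C@H](C(C)(C)NC(=S)N/N=C/c2cccc([N+](=O)[O-])c2)CC1`: > 100000 nM (a limit)

Going by the values given here, in a functional assay on OVCAR-3 cells (Homo sapiens) for inhibition, read by sulforhodamine B assay, with a stated time of 48 h (on this read-out lower numbers stand for stronger inhibition of growth and higher numbers for weaker inhibition of growth), compound 1 gives 21200 nM, the only genuine number among the three measured compounds. For compound 2 the assay reports no number but a limit, > 100000 nM. For compound 3 it likewise reports only a limit, > 100000 nM. Among the compounds with values here, the single measured step, an at least 4.7-fold higher number from compound 1 to compound 2 (0.67 log units; beyond the scatter), therefore has a size bounded by the limit of > 100000 nM in this assay, at which 2 of the 3 values shown sit, rather than by a second number.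

Compound 4 `CC1=CC[C@H](C(C)(C)NC(=S)N/N=C/c2ccco2)CC1` differs from compound 1 by furan-2-yl in place of 4-methoxyphenyl on a carbon with a double bond to nitrogen. Within the data shown here, no measured step exchanges the aromatic ring itself; the one step recorded alters only a substituent on that ring, and it points towards weaker inhibition of growth. On that thin basis a move of similar direction is expected for compound 4 in this assay, a 1.9-fold higher number from compound 1 to compound 4 (0.28 log units; within the scatter), with a fair chance that only a limit is returned. Compound 4 is thus estimated at 40000 nM, within a range of 12000 nM to 100000 nM.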

Compound 4, concentration for total growth inhibition: 13800 nM
For compound 4 the middle estimate is 2.9-fold (0.46 log units) above the measured one; the range from low to high includes it.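

In this assay, going by these compounds alone, the first exchange of the aromatic ring itself gives a 1.5-fold lower number from compound 1 to compound 4 (0.19 log units; within the scatter), so on the carbon with a double bond to nitrogen, furan-2-yl and 4-methoxyphenyl cannot be told apart in this read-out. The earlier step changed only a substituent on the ring, whereas here a five-membered aromatic ring with 1 hetero atom replaces a six-membered aromatic ring of carbon only, and a genuine number is still returned. Compound 2 and compound 3 remain at a limit, not a number: the limit of > 100000 nM in this assay, at which 2 of the 4 values shown sit.

The compounds shown leave open whether a thiophene or a pyridine in place of the furan would also return a genuine number, and whether a methyl group or a bromine on the furan would shift it. They also leave open how a hydroxyl in place of the methoxy of compound 1 would read.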